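Cyclohexylamide in place of the acid: cell tolerance

The source may hold more compounds than are shown below. What is called first, only, known or untested is meant among the compounds shown, and "the series" means these compounds.

Measured so far:
compound 1 `COc1cccc(OC)c1C(=O)Nc1c[nH]nc1C(=O)O`
compound 2 `CO[C@H]1CC[C@H](NC(=O)c2n[nH]cc2NC(=O)c2ccc(F)cc2F)CC1`

In an ADME assay on MRC5 cells (Homo sapiens) for inhibition, with a stated time of 72 h (on this read-out higher numbers stand for an effect only at larger amounts of compound and lower numbers for an effect already at smaller amounts), compound 1 is reported only as a limit, > 50000 nM. Compound 1 therefore stands at the limit of > 50000 nM in this assay, at which 1 of the 2 values shown sits; it sits at the edge of what the read-out records, with no number to place it against the other value. Within the data shown here, compound 2 gives 11000 nM in this assay, the only full number in the set.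

Compound 3 `COc1cccc(OC)c1C(=O)Nc1c[nH]nc1C(=O)NC1CCC(C)CC1` differs from compound 1 in one place: (4-methylcyclohexyl)amino in place of hydroxy on a carbonyl carbon. Among the measured compounds shown here, no step between two measured compounds covers this change, so its size in this assay cannot be read from a measured pair. For the measured compounds named here, compound 2, the one measured compound with a number, gives 11000 nM, and on that basis compound 3 is expected to show an effect at smaller amounts than compound 1, an expected step of an at least 3.3-fold lower number from compound 1 to compound 3 (0.52 log units; beyond the scatter) that would lie beyond the scatter. The estimate for compound 3 in this assay is 15000 nM, with an expected range from 4000 nM to 50000 nM.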

Compound 3, half-maximal effective concentration: 45000 nM
Compound 3: middle estimate off by 3.0-fold (0.48 log units), on the low side, within the range that was stated.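

In this assay, among these compounds, the (4-methylcyclohexyl)amino group on the carbonyl carbon gives the first full number on the core of compound 1, with compound 3 at 45000 nM, still within what the read-out records. Compound 1 stands at > 50000 nM, which is a limit of the assay and not a number. The change therefore reads only as an at least 1.1-fold lower number from compound 1 to compound 3 (0.04 log units; that floor lies within the scatter), and its size stays a floor with no upper bound because one end of the step is a limit: the limit of > 50000 nM in this assay, at which 1 of the 3 values shown sits.

Compound 3 and compound 2 differ in more than one place, so the compounds shown do not separate what the amide contributes from what the other differences contribute, and whether the number for compound 3 marks a real move away from the acid remains open. Also open, from the compounds shown here alone, is how an amide of unsubstituted cyclohexylamine, of morpholine or of a longer open-chain amine would sit in this assay, and with that, whether the ring, the methyl group on it or the loss of the carboxylic acid matters here.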